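The compounds below may be only part of what the source reports. "The series", "measured", "known", "first", "only" and "open" are said of these compounds alone.

Compound 1 `NC1CCC(Nc2nc(NCc3ccc(-c4cccc(F)c4)nc3)c3ncn(C4CCCC4)c3n2)CC1`: 61 nM
Compound 2 `NC1CCC(Nc2nc(NCc3ccc(-c4cccs4)nc3)c3ncn(C4CCCC4)c3n2)CC1`: 100 nM

Only these two compounds have been measured in a functional assay on K562 cells (Homo sapiens) for inhibition, with a stated time of 72 h; on this read-out lower numbers stand for stronger inhibition and higher numbers for weaker inhibition. Going by the values given here, compound 2, at 100 nM, lies within the scatter of the only other value. Compound 3 `NC1CCC(Nc2nc(NCc3ccc(-c4ccccc4O)nc3)c3ncn(C4CCCC4)c3n2)CC1` has not yet been measured. It carries 2-hydroxyphenyl in place of thiophen-2-yl on an aromatic carbon.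

Among the compounds with values here, one measured step bears on this change, since it exchanged a group at the same place. That step is a 1.6-fold higher number from compound 1 to compound 2 (0.21 log units; within the scatter), with thiophen-2-yl in place of 3-fluorophenyl, and it stays within the scatter. Within the data shown here, no measured compound carries 2-hydroxyphenyl, so this evidence is thin. On that single step, no change beyond the scatter is expected in this assay, and no direction is favoured. The expected step is a 1.1-fold lower number from compound 2 to compound 3 (0.05 log units; within the scatter). For compound 3 the estimated value is 90 nM, with an expected range from 30 nM to 270 nM.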

Compound 3, half-maximal inhibitory concentration: 16 nM
The estimate for compound 3 lay 5.6-fold (0.75 log units) above the measured number; measured number outside the range, below it.
By their numbers in this assay, from the lowest: compound 3; then compounds 1 and 2 (each within the scatter of the next).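

In this assay, the place next to the ring nitrogen and para to a large group proves sensitive to the group it carries: 2-hydroxyphenyl gives a 6.3-fold lower number from compound 2 to compound 3 (0.80 log units; beyond the scatter) and also a 3.8-fold lower number from compound 1 to compound 3 (0.58 log units; beyond the scatter), both beyond the scatter, whereas the exchange of 3-fluorophenyl for thiophen-2-yl had stayed within it. Compared with thiophen-2-yl, the entering group differs in having a six-membered aromatic ring of carbon only and 1 hydrogen-bond donor, and the three compounds cannot separate these two differences. No measurement at hand explains the lower number.

As far as these compounds go, it remains open whether the hydroxyl itself matters, which unsubstituted phenyl, 2-methoxyphenyl or 2-aminophenyl would help to settle. From the compounds shown here alone, whether the hydroxyl must sit at this place on the ring is also open, a question for 3-hydroxyphenyl and 4-hydroxyphenyl.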